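Working notes: from compound 2 to compound 4

A few compounds are considered here, and "the series" means these few. Any claim that something is new, unique, unknown or untested is made for them only; others in the source may bear on it.

Measured so far in a functional assay on DLD-1 cells (Homo sapiens) for cytotoxicity, read by resazurin assay, with a stated time of 48 h; a higher number here means that more compound is needed for the effect, a lower number that less compound is needed
Compound 1 `COc1ccc(S(=O)(=O)Nc2ccc(-c3nc4cc(NS(=O)(=O)c5ccc(OC)cc5)ccc4o3)cc2)cc1` gives 28000 nM
Compound 2 `COc1ccc(S(=O)(=O)Nc2ccc3oc(-c4ccc(NC(=O)c5cccc(C)c5[N+](=O)[O-])cc4)nc3c2)cc1` gives 1500 nM
Compound 3 `O=S(=O)(Nc1ccc(-c2nc3cc(NS(=O)(=O)c4ccc(Br)cc4)ccc3o2)cc1)c1ccc(Br)cc1` gives 16000 nM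

Compound 2 at 1500 nM has the lowest number of the three, and compound 1 and compound 3 both stand well beyond the scatter above it. Compound 4 `COc1ccc(S(=O)(=O)Nc2ccc3oc(-c4ccc(NC(=O)c5ccc(Cl)s5)cc4)nc3c2)cc1` carries 5-chlorothiophen-2-yl in place of 3-methyl-2-nitrophenyl on a carbonyl carbon.

Within the data shown here, the only measured step that bears on this is large: a 19-fold lower number from compound 1 to compound 2 (1.27 log units; beyond the scatter) with (3-methyl-2-nitrophenyl)carbonyl in place of (4-methoxyphenyl)sulfonyl on a nitrogen on an aromatic ring. Compound 4 keeps a carbonyl there, as compound 2 at 1500 nM does, so its number is expected to stay close to that value. Among the measured compounds shown here, no measured step exchanges one group on this carbonyl for another, so the size of this change remains open and the range is wide. The estimate is a 1.3-fold higher number from compound 2 to compound 4 (0.12 log units; within the scatter) so no step beyond the scatter is expected in this assay for this exchange. The expected value for compound 4 is 2000 nM with an estimated range from 700 nM to 7000 nM for the coming measurement.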

Compound 4, half-maximal effective concentration: 4600 nM
Beside the measured number, compound 4's estimate is 2.3-fold (0.36 log units) below it, and the stated range covers the measured number.
By their numbers in this assay, from the lowest: compound 2; then compound 4; then compounds 3 and 1 (each within the scatter of the next).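

Among these compounds, compound 4 gives the first reading of an exchange on this carbonyl carbon, and in this assay the group there matters, with a 3.1-fold higher number from compound 2 to compound 4 (0.49 log units; beyond the scatter) for 5-chlorothiophen-2-yl in place of 3-methyl-2-nitrophenyl. The lower number against the sulfonyl compound is not confined to one carbonyl group, since (5-chlorothiophen-2-yl)carbonyl in place of (4-methoxyphenyl)sulfonyl still gives a 6.1-fold lower number from compound 1 to compound 4 (0.78 log units; beyond the scatter) and sits alongside the larger 19-fold lower number from compound 1 to compound 2 (1.27 log units; beyond the scatter) as a second case in the same direction. No measurement shown gives a reason for either new step.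

The exchange alters the ring, the nitro group, the methyl and the chlorine together, and the compounds shown do not separate their contributions. Also open, from the compounds shown here alone, is how a plain phenyl, an amine-bearing ring or a longer chain on this carbonyl would read.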